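The source may report more compounds than this note shows. Statements on the series, on what has been measured and on what is new or still open speak of the compounds shown alone.

Measured compounds:
Compound 1 `O=c1[nH]/c(=N\OCCCc2ccc(F)cc2)ccn1[C@@H]1O[C@H](COP(=O)(O)OP(=O)(O)OP(=O)(O)O)[C@@H](O)[C@H]1O` gives 105 nM in a functional assay on 1321-N1 cells for agonist activity at P2Y purinoceptor 4 (Homo sapiens), read by scintillation counting and inositol phosphate accumulation; a higher number here means that more compound is needed for the effect, a lower number that less compound is needed.
Compound 2 `O=c1[nH]/c(=N\OCCCc2ccc(Br)cc2)ccn1[C@@H]1O[C@H](COP(=O)(O)OP(=O)(O)OP(=O)(O)O)[C@@H](O)[C@H]1O` gives 141 nM in this assay.
Compound 3 `COc1ccc(CCCO/N=c2/ccn([C@@H]3O[C@H](COP(=O)(O)OP(=O)(O)OP(=O)(O)O)[C@@H](O)[C@H]3O)c(=O)[nH]2)cc1` gives 23 nM in this assay.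

All three share one core and differ only in the group on the aromatic ring at the end of the chain. Compound 3, carrying methoxy, stands lowest of the three numbers: the step of a 4.6-fold lower number from compound 1 to compound 3 (0.66 log units; beyond the scatter) and the step of a 6.1-fold lower number from compound 2 to compound 3 (0.79 log units; beyond the scatter) both lie beyond the scatter, while the step of a 1.3-fold higher number from compound 1 to compound 2 (0.13 log units; within the scatter) does not.

Compound 4 `C#CCCNC(=O)COc1ccc(CCCO/N=c2/ccn([C@@H]3O[C@H](COP(=O)(O)OP(=O)(O)OP(=O)(O)O)[C@@H](O)[C@H]3O)c(=O)[nH]2)cc1` keeps the whole of compound 3 and adds (a group of 7 heavy atoms (5 carbon, 1 nitrogen, 1 oxygen; no ring) in place of a hydrogen atom, on a saturated chain carbon bound to an oxygen on an aromatic ring). Going by the values given here, no measured step touches this position; the two informative steps only exchanged the group on the aromatic carbon, and both favoured methoxy. Among the compounds with values here, the new change therefore has no direct precedent here, and the reasonable expectation is a small step, if any, in this assay. The step of a 1.7-fold higher number from compound 3 to compound 4 (0.24 log units; within the scatter) is the estimated outcome. Compound 4 is thus expected to give about 40 nM, within a range from 12 nM to 130 nM.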

Compound 4, half-maximal effective concentration: 40 nM
Compound 4: the middle estimate sits on the measured number at the digits printed; measured number inside the range.
By their numbers in this assay, from the lowest: compounds 3 and 4 (each within the scatter of the next); then compounds 1 and 2 (each within the scatter of the next).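

Putting a group of 7 heavy atoms (5 carbon, 1 nitrogen, 1 oxygen; no ring) in place of a hydrogen atom, on a saturated chain carbon bound to an oxygen on an aromatic ring, gives a 1.7-fold higher number from compound 3 to compound 4 (0.24 log units; within the scatter) in this assay, so this position accepts a much larger group without a step that stands out from the scatter. The much larger substituent also keeps the lower number against both halogens, with a 3.5-fold lower number from compound 2 to compound 4 (0.55 log units; beyond the scatter) and a 2.6-fold lower number from compound 1 to compound 4 (0.42 log units; beyond the scatter), which shows that the gain seen with methoxy is not confined to that small group. Nothing available explains why this position accepts the addition.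

Only one group at this position is shown, so it remains open whether the triple bond matters. A carboxylic acid, an amine or a longer chain in the same place could give quite different numbers.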